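This account rests on a few compounds, and the source may have more. Where it says the series, first, only, none or still open, it means among the compounds named here.

Measured so far:
compound 1 `CCCCOc1ccc(C2CNC(=O)C2)cc1OC` — > 1000000 nM
compound 2 `C=CCOc1cc(C2CNC(=O)C2)ccc1OC` — > 1000000 nM

In an assay on isolated protein for inhibition of phosphodiesterase 1 (Bos taurus), read by cGMP accumulation, in the presence of a further agent that is not named here (on this read-out higher numbers stand for weaker inhibition and lower numbers for stronger inhibition), compound 1 gives > 1000000 nM, which is a limit of the assay and not a number. In this assay compound 2 gives > 1000000 nM, likewise only a limit. Among the compounds with values here, compound 2 thus stands at the limit of > 1000000 nM in this assay, at which 2 of the 2 values shown sit, with no measured step between the two compounds to lean on.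

Compound 3 `COc1ccc(C2CNC(=O)C2)cc1OCCCC(=O)O` differs from compound 2 by 2-carboxyethyl in place of vinyl on a saturated chain carbon bound to an oxygen on an aromatic ring. With compound 2 only at a limit, the expected step from compound 2 to compound 3 is a number no higher from compound 2 to compound 3 (the limit leaves the size open), none beyond the scatter. Compound 3 is expected at 1000000 nM, between 300000 nM and 3000000 nM.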

Compound 3, half-maximal inhibitory concentration: > 1000000 nM
Compound 3 ended at the assay's limit; the forecaster's own chance of this, stated with the estimate: 85%; the middle value lies on the limit itself.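

No step can be read from compound 2 to compound 3, as both values are limits and not numbers: the limit of > 1000000 nM in this assay, at which 3 of the 3 values shown sit.

The compounds shown leave open whether 2-carboxyethyl in place of vinyl changes inhibition at all, and which structure in this series would give a number rather than a limit.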